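Notes on the chloro-to-methyl step in this series

This account rests on a few compounds, and the source may have more. Where it says the series, first, only, none or still open, it means among the compounds named here.

Measured compounds:
- compound 1, `CNCc1cc(-c2cccnc2F)n(S(=O)(=O)c2cccnc2)c1`: 96%
- compound 2, `CNCc1cc(-c2cccnc2Cl)n(S(=O)(=O)c2cccnc2)c1`: 92%

Both measured compounds were run in a functional assay on the whole organism (strain Jcl:SD) for inhibition, with Rattus norvegicus as the target, with stated times of 3 min and 3 h, at a dose of 1 mg/kg by the intravenous route; on this read-out lower numbers stand for less inhibition and higher numbers for more inhibition at the one dose given (going by the name of the read-out). Compound 1 gives 96%, and compound 2 gives 92%. Compound 2 stands as the lower of the two numbers; its nearest neighbour is compound 1, and the step of a number 4 percentage points lower from compound 1 to compound 2 (within the scatter) is stated to lie within the scatter, so no order between the two can be claimed.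

Compound 3, `CNCc1cc(-c2cccnc2C)n(S(=O)(=O)c2cccnc2)c1`, has not yet been measured. It differs from compound 2 as follows: methyl in place of chloro on an aromatic carbon.

For the measured compounds named here, the only measured step bears on a different exchange at the same aromatic carbon, and it was a number 4 percentage points lower from compound 1 to compound 2 (within the scatter), within the scatter. Going by the values given here, no measured pair covers methyl in place of chloro, so the expectation rests on the near-flat behaviour seen so far. A step of a number 2 percentage points lower from compound 2 to compound 3 (within the scatter) is expected, which is no change beyond the scatter.

Compound 3 is therefore estimated at 90%, with a range from 78% to 97%.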

Compound 3, a percentage reported as inhibition, in the whole organism at one dose (the size of the read-out at that dose, not a potency): -41%
Estimate against measurement, compound 3: 131 percentage points above; measured number outside the range, below it.
By their numbers in this assay, from the lowest: compound 3; then compounds 2 and 1 (each within the scatter of the next).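

In this assay this position next to the ring nitrogen does not accept every exchange: replacing either halogen with methyl gives two large steps, a number 133 percentage points lower from compound 2 to compound 3 (beyond the scatter) and a number 137 percentage points lower from compound 1 to compound 3 (beyond the scatter), so the near-flat behaviour seen earlier holds only for the fluoro and chloro pair. The exchange from 2-chloropyridin-3-yl to 2-methylpyridin-3-yl replaces one heavy atom with one heavy atom and leaves the counted hydrogen-bond donors, acceptors and net charge unchanged, so these counts do not separate compound 2 from compound 3, and compound 3 reaches -41% on the same core. Nothing available here gives a measured explanation for this drop.

The compounds shown leave open whether the drop belongs to methyl alone or extends to other carbon groups at this place, such as an ethyl chain or trifluoromethyl, and how a methoxy group, an amine or a nitrile would read. They also leave open how compound 3 would behave at other doses, as each number in this assay comes from one dose and is not a potency.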